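A few compounds are considered here, and "the series" means these few. Any claim that something is new, unique, unknown or untested is made for them only; others in the source may bear on it.

Working notes on the series.

Of the compounds shown here, two carry numbers so far. Compound 1 `CN1CCc2nc(C#Cc3ccc(Cl)cc3)ccc2C1=O` gives 6150 nM in an assay on HEK293 cells for displacement of a labelled ligand from metabotropic glutamate receptor 5 (Homo sapiens), with a stated time of 2 h; on this read-out lower numbers stand for stronger inhibition and higher numbers for weaker inhibition. Compound 2 `CC(C)N1CCc2nc(C#Cc3ccccc3)ccc2C1=O` gives 1280 nM in this assay, the lower of the two numbers; compound 1 stands at a higher number, beyond the scatter. Within the data shown here, compound 1 and compound 2 differ in more than one place, so no single step joins them and the two values only show the gap between them.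

Compound 3 `CC(C)N1CCc2nc(C#Cc3cccc(Cl)c3)ccc2C1=O` is not yet measured. It departs from compound 2 by one change: chloro in place of hydrogen on an aromatic carbon, meta to a large group. Among the measured compounds shown here, nothing among the measured compounds isolates this change, so the expected step rests on the starting point alone. The step from compound 2 to compound 3 in this assay is expected to be small, toward lower numbers, and may well stay within the scatter: a 1.7-fold lower number from compound 2 to compound 3 (0.23 log units; within the scatter). On that basis compound 3 is estimated at 750 nM in this assay, with an expected range from 200 nM to 2800 nM.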

Compound 3, inhibition constant: 100 nM
The estimate for compound 3 lay 7.5-fold (0.88 log units) above the measured number; measured number outside the range, below it.
By their numbers in this assay, from the lowest: compound 3; then compound 2; then compound 1.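

The step from phenyl to 3-chlorophenyl gives the series its first single-place reading in this assay: a 13-fold lower number from compound 2 to compound 3 (1.11 log units; beyond the scatter), a large step beyond the scatter, so this aromatic carbon, meta to a large group, is a place where chloro in place of hydrogen changes the number strongly. Compound 1 also carries a chloro group, but it differs from compound 3 in more than one place, so it cannot show whether the same change would behave alike elsewhere on the ring or with another group on the amide nitrogen. The data shown include no independent measurement that would explain the size of this step.

On these data alone, it remains open whether fluoro, bromo, methyl, methoxy, trifluoromethyl or nitrile in place of the chloro on this same carbon would give a step of similar size, or whether the chloro is particular in this respect. As far as these compounds go, it also remains open whether the step would persist with a methyl, cyclopropyl or longer alkyl chain in place of the group on the amide nitrogen of compound 3.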